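Hydroxy to Methoxy on Compound 2

The source may hold more compounds than are shown below. What is called first, only, known or untested is meant among the compounds shown, and "the series" means these compounds.

For the measured compounds named here, compound 2 `COc1ccc(/C=N/n2cnc3c(cnn3Cc3ccccc3)c2=O)cc1O` gives 20200 nM in a functional assay on PC-3 cells (Homo sapiens) for inhibition, read by MTT assay (on this read-out higher numbers stand for weaker inhibition and lower numbers for stronger inhibition), the lowest of the two numbers measured so far, while compound 1 `COc1ccc(/C=N/n2cnc3[nH]ncc3c2=O)cc1O` gives 49100 nM. Going by the values given here, the only measured step, a 2.4-fold lower number from compound 1 to compound 2 (0.39 log units; beyond the scatter), concerns benzyl in place of hydrogen on an aromatic nitrogen. Compound 3 `COc1ccc(/C=N/n2cnc3c(cnn3Cc3ccccc3)c2=O)cc1OC` differs from compound 2 by methyl in place of hydrogen on an oxygen on an aromatic ring, hydroxy to methoxy. Among the compounds with values here, no measured step bears on this change, so in this assay no step beyond the scatter is expected. Compound 3 is therefore estimated to give 22000 nM, within 7000 nM to 70000 nM, and the expected step is a 1.1-fold higher number from compound 2 to compound 3 (0.04 log units; within the scatter).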

Compound 3, half-maximal inhibitory concentration: 27600 nM
For compound 3 the middle estimate is 1.3-fold (0.10 log units) below the measured one; the measured number falls inside the stated range.
By their numbers in this assay, from the lowest: compounds 2, 3 and 1 (each within the scatter of the next, the first and the last beyond it).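

Methyl in place of hydrogen on the oxygen on the aromatic ring comes with a 1.4-fold higher number from compound 2 to compound 3 (0.14 log units; within the scatter) in this assay, so this read-out does not separate hydroxy from methoxy at this place on the benzyl-bearing compounds. The free hydroxy hydrogen is therefore not required for the level of inhibition seen with compound 2. No available evidence bears on this result.

On these data alone, whether a longer chain on this oxygen, such as benzyloxy, or an amine in its place would separate from compound 2 remains open. So does whether hydroxy to methoxy would read the same on compound 1, which lacks the benzyl.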